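Swapping a cyclic urea for an oxadiazolone on the shared core

This account rests on a few compounds, and the source may have more. Where it says the series, first, only, none or still open, it means among the compounds named here.

Measured compounds:
- compound 1 `CC(C)C(c1ccc(-c2ccc3cccc(F)c3c2)[nH]c1=O)N1CCNC1=O`: 1.03 h
- compound 2 `CCC(CC)(c1nnc[nH]1)c1ccc(-c2ccc3cccc(F)c3c2)[nH]c1=O`: 1.19 h

In an ADME assay on microsomes from liver (Homo sapiens) for metabolic stability (a lower number here means that the compound disappears faster, a higher number that the compound lasts longer), compound 1 gives 1.03 h and compound 2 gives 1.19 h; the two numbers sit within the scatter of each other, so neither can be called more stable. Compound 3 `CC(C)C(Cc1noc(=O)[nH]1)c1ccc(-c2ccc3cccc(F)c3c2)[nH]c1=O` is not yet measured. It differs from compound 1 by a group of 7 heavy atoms (3 carbon, 2 nitrogen, 2 oxygen; one five-membered aromatic ring with 3 hetero atoms) in place of a group of 6 heavy atoms (3 carbon, 2 nitrogen, 1 oxygen; one five-membered non-aromatic ring with 2 hetero atoms), on a saturated chain carbon bound to an aromatic carbon and a saturated chain carbon. Among the compounds with values here, no measured pair shows what such a change does, so the step from compound 1 to compound 3 is expected to stay within the scatter, a 1.0-fold lower number from compound 1 to compound 3 (0.01 log units; within the scatter). For compound 3 a half-life of 1 h is estimated, between 0.5 h and 2 h.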

Compound 3, half-life: > 3 h
Compound 3: a limit, no number; the forecaster's own chance of this, stated with the estimate: 5%; at least 3.0-fold (0.47 log units) between middle value and limit.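

At this saturated chain carbon, the group carried does matter in this assay: putting the five-membered aromatic ring with 3 hetero atoms in place of 2-oxoimidazolidin-1-yl gives an at least 2.9-fold higher number from compound 1 to compound 3 (0.46 log units; beyond the scatter). Compound 3 gives > 3 h, which is a limit and not a number. The full size of the step therefore stays unknown: the limit of > 3 h in this assay, at which 1 of the 3 values shown sits.

The compounds shown cannot tell which feature of the entering group produces the step. They also leave open whether a carboxylic acid or an amine at this place would last as long.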